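A few compounds are considered here, and "the series" means these few. Any claim that something is new, unique, unknown or untested is made for them only; others in the source may bear on it.

Measured compounds:
- compound 1, `CCC(Oc1cc(C)nc2ccc(OC)cc12)C(=O)Nc1cc(C)cc(C)c1`: 123000 nM
- compound 2, `COc1ccc2nc(C)cc(OCC(=O)NCc3cc(C)cc(C)c3)c2c1`: 92000 nM

In a physicochemical assay for solubility, in phosphate buffer, measured as kinetic solubility, with a stated time of 1 h, at pH 7.4 (a higher number here means a more soluble compound, a lower number a less soluble compound), compound 2 stands at the lowest of the two numbers, with compound 1 the nearest at a higher value; that gap lies within the scatter of repeated measurements, so the two cannot be ordered. The unmeasured compound 3, `COc1ccc2nc(C)cc(OCC(=O)Nc3cc(C)ccc3OC)c2c1`, arises from compound 2 by a single exchange: 2-methoxy-5-methylphenyl in place of 3,5-dimethylbenzyl on an amide-type nitrogen. Among the compounds with values here, no step between measured compounds touches this position, so there is nothing to calibrate the size of the change. Compound 1 carries an aryl group directly on the amide nitrogen, as compound 3 will, and its number in this assay sits close to that of compound 2. On that basis the author expects no step beyond the scatter, with the estimated move from a 1.1-fold higher number from compound 2 to compound 3 (0.04 log units; within the scatter) small. Compound 3 is expected to give about 100000 nM, within a range from 40000 nM to 250000 nM.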

Compound 3, solubility: 9500 nM
The estimate for compound 3 lay 11-fold (1.02 log units) above the measured number, outside the stated range (below it).
By their numbers in this assay, from the lowest: compound 3; then compounds 2 and 1 (each within the scatter of the next).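

In this assay the amide-type nitrogen proves to be a place that responds: 2-methoxy-5-methylphenyl in place of 3,5-dimethylbenzyl gives a clear drop (a 9.7-fold lower number from compound 2 to compound 3 (0.99 log units; beyond the scatter)), beyond the scatter. The group that leaves and the group that enters have the same number of heavy atoms and each holds one six-membered aromatic ring of carbon only, so these counts alone do not fix the read-out at this place. No measurement shown here accounts for the size of this step.

The compounds shown leave open whether the step follows the methoxy group, the methyl group or the change from a benzyl to a phenyl, as the exchange alters these together. They also leave open how a plain phenyl, or a phenyl carrying an amine or a carboxylic acid, would read at this nitrogen.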